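A few compounds are considered here, and "the series" means these few. Any claim that something is new, unique, unknown or untested is made for them only; others in the source may bear on it.

Compound 1 `COc1c(Br)cccc1C(=O)Nc1ccccc1`: in an assay for inhibition of HSP60/HSP10 (Homo sapiens), with a stated time of 60 min (a higher number here means a weaker inhibitor, a lower number a stronger inhibitor), compound 1 gives > 100000 nM, a limit of the assay.
Compound 2 `O=C(Nc1ccccc1)c1cccc(Br)c1`: in this assay compound 2 gives > 100000 nM, again a limit of the assay.
Compound 3 `O=C(Nc1ccccc1)c1cc(Br)cc(Br)c1O`: in this assay compound 3 gives 63000 nM.

Among the measured compounds shown here, compound 3 thus stands as the only compound with a measured number, the others resting at the limit of > 100000 nM in this assay, at which 2 of the 3 values shown sit. Compound 4 `O=C(Nc1ccccc1)c1cccc(Br)c1O` differs from compound 3 by hydrogen in place of bromo on an aromatic carbon. For the measured compounds named here, no measured step covers this change: the one step available, a step that the two limits leave unreadable from compound 1 to compound 2, concerns a different group and its size cannot be read. With compound 3 already weak and the remaining compounds at the limit, compound 4 is expected to be weaker still, with a 2.4-fold higher number from compound 3 to compound 4 (0.38 log units; beyond the scatter), and is likely to reach the limit. The estimate for compound 4 is 150000 nM, within 40000 nM to 600000 nM.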

Compound 4, half-maximal inhibitory concentration: > 100000 nM
Compound 4 gave a limit, no number; the forecaster's own chance of this, stated with the estimate: 70%; the middle value is on the limit's open side.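

Removing the bromo group para to the hydroxy group gives an at least 1.5-fold higher number from compound 3 to compound 4 (0.20 log units; that floor lies within the scatter), so losing this group may weaken binding, but the size of that loss remains uncertain. Compound 4 keeps the hydroxy group yet gives only a limit, so that group alone does not bring a number into range, and its steps from compound 1 and compound 2 join limit to limit and cannot be read. Most of the set now rests at one edge: the limit of > 100000 nM in this assay, at which 3 of the 4 values shown sit.

On these data alone, whether chlorine, a methyl or an amine at this position would keep the activity of compound 3 stays open. So does how the hydroxy group contributes when the bromo groups of compound 3 are kept.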